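The compounds below may be only part of what the source reports. "The series", "measured", "known", "first", "only" and "open" are said of these compounds alone.

Measured in a functional assay on MDA-MB-231 cells (Homo sapiens) for antiproliferative activity, with a stated time of 4 days; on this read-out higher numbers stand for weaker inhibition and lower numbers for stronger inhibition:
compound 1, `CCCCCCc1ccc2[nH]c(-c3ccc(OC)cc3)c(C=O)c2c1`, 7.4 nM
compound 2, `CCCCCCc1ccc2[nH]c(-c3ccc(C(F)(F)F)cc3)c(C=O)c2c1`, 43 nM
compound 3, `CCCCc1ccc2[nH]c(-c3ccc(OC)cc3)c(/C=N\C)c2c1`, 6 nM

Compound 2 differs from compound 1 in a single place, (trifluoromethyl in place of methoxy on an aromatic carbon), and that change produced a 5.8-fold higher number from compound 1 to compound 2 (0.76 log units; beyond the scatter). Compound 3 gives a number close to that of compound 1, and the difference between the two cores is not broken down here. Compound 4, `CCCCc1ccc2[nH]c(-c3ccc(C(F)(F)F)cc3)c(/C=N\C)c2c1`, has not yet been measured in this assay. Within the data shown here, it differs from compound 3 by trifluoromethyl in place of methoxy on an aromatic carbon, which is the same change at the same place as the one separating compound 1 from compound 2. Among the measured compounds shown here, only one measured example of this change exists, so the expectation rests on a single comparison: the expected step is a 5.8-fold higher number from compound 3 to compound 4 (0.77 log units; beyond the scatter), because a 5.8-fold higher number from compound 1 to compound 2 (0.76 log units; beyond the scatter) is the sole precedent for swapping these two groups on that ring. Compound 4 is therefore expected to give about 35 nM, with a likely range from 12 nM to 100 nM.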

Compound 4, half-maximal inhibitory concentration: 32 nM
The estimate for compound 4 lay 1.1-fold (0.04 log units) above the measured number; measured number inside the range.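

In this assay, putting trifluoromethyl in place of methoxy on the aromatic carbon of the core of compound 3 gave a 5.3-fold higher number from compound 3 to compound 4 (0.73 log units; beyond the scatter). Set beside the earlier example, the change had a similar effect on both cores: the same change on two cores in this assay, a 5.8-fold higher number (0.76 log units; beyond the scatter) from compound 1 to compound 2 and a 5.3-fold higher number (0.73 log units; beyond the scatter) from compound 3 to compound 4, 1.1-fold (0.04 log units) apart, within the scatter of two such steps. Among these compounds, this shows that the size of the step carried over between these two cores in this assay, but it rests on only two pairs of compounds, so it does not show that the step would hold on any further core, and it does not explain why the change acts as it does.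

The compounds shown carry only methoxy or trifluoromethyl on that aromatic carbon, so how a nitrile or an amine there would behave remains open. As far as these compounds go, compound 1 and compound 3 differ in more than one place, so what each of those differences contributes on its own also remains open.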